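This account rests on a few compounds, and the source may have more. Where it says the series, first, only, none or still open, it means among the compounds named here.

Measured so far in a functional assay on HOS-TE85 cells (Homo sapiens) for inhibition, read by CCK-8 assay, with a stated time of 72 h; a lower number here means a stronger inhibitor, a higher number a weaker inhibitor:
compound 1 `O=C(NCCCCc1ccccc1)c1cc(F)cc(C2SCC(=O)N2c2ccccn2)c1` — 14.2 nM
compound 2 `O=C(NCCCCc1ccccc1)c1cccc(C2SCC(=O)N2c2ccccc2)c1` — 15.9 nM
compound 3 `COc1ccccc1N1C(=O)CSC1c1cccc(C(=O)NCCCCc2cccs2)c1` — 46 nM

Compound 2 holds the second highest of the three numbers. Its nearest neighbour is compound 1, whose value lies within the scatter of the value of compound 2, so the two cannot be told apart. Compound 3 sits furthest off, with a higher number beyond the scatter, and is the weaker inhibitor of that pair in this assay.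

Compound 4 `O=C(NCCCCc1ccccc1)c1cccc(C2SCC(=O)N2c2ccccc2F)c1` is not yet measured. It differs from compound 2 by fluoro in place of hydrogen on an aromatic carbon, read one bond further out as phenyl to 2-fluorophenyl. Among the compounds with values here, no measured pair in the set shows this difference, so there is no step to lean on. In this assay the change is expected to give nothing beyond the scatter, in no settled direction, as a 1.0-fold higher number from compound 2 to compound 4 (0.00 log units; within the scatter). Compound 4 is therefore estimated at 16 nM, with a range from 7 nM to 36 nM.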

Compound 4, half-maximal inhibitory concentration: 34.1 nM
Compound 4: the middle estimate sits 2.1-fold (0.33 log units) below what was measured; the measured number falls inside the stated range.
By their numbers in this assay, from the lowest: compounds 1 and 2 (each within the scatter of the next); then compounds 4 and 3 (each within the scatter of the next).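

In this assay, within the data shown here, phenyl to 2-fluorophenyl is the first change in one place that can be read, and it gives a 2.1-fold higher number from compound 2 to compound 4 (0.33 log units; beyond the scatter). A single fluoro on this aromatic carbon, ortho to a large group, is therefore not silent here: this position responds to one added heavy atom, towards weaker inhibition. Nothing measured bears on the cause of this step.

On these data alone, whether chloro or methyl on the same carbon shifts the number further remains open. So does whether fluoro elsewhere on this ring gives a similar step.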